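This account rests on a few compounds, and the source may have more. Where it says the series, first, only, none or still open, it means among the compounds named here.

Within the data shown here, compound 2 `O=C(CN1CCN(c2nnc(Cc3ccncc3)c3ccccc23)CC1)Nc1cccc(F)c1` is one of two compounds measured so far in a functional assay on A549 cells (Homo sapiens) for cytotoxicity, read by MTT assay, with a stated time of 72 h; on this read-out lower numbers stand for stronger inhibition and higher numbers for weaker inhibition. Compound 2 gives 4600 nM, the higher of the two numbers, and its nearest neighbour is compound 1 `O=C(CN1CCN(c2nnc(Cc3ccncc3)c3ccccc23)CC1)Nc1ccc(F)c(F)c1`, which in this assay gives 3790 nM. These two differ by hydrogen in place of fluoro on an aromatic carbon, and the step of a 1.2-fold higher number from compound 1 to compound 2 (0.08 log units; within the scatter) is too small to count as a real difference.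

Compound 3 `Cc1ccccc1NC(=O)CN1CCN(c2nnc(Cc3ccncc3)c3ccccc23)CC1` has not yet been measured. It differs from compound 2 in one place: 2-methylphenyl in place of 3-fluorophenyl on an amide-type nitrogen. Among the measured compounds shown here, no measured step bears directly on this change; the only step known, from compound 1 to compound 2, concerns a fluoro group and stays within the scatter. With nothing to suggest a shift, compound 3 is expected to give about 4500 nM, within a range of 2000 nM to 10000 nM. This estimate means a step of a 1.0-fold lower number from compound 2 to compound 3 (0.01 log units; within the scatter), which is expected to lie within the scatter.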

Compound 3, half-maximal inhibitory concentration: 43100 nM
The estimate for compound 3 lay 9.6-fold (0.98 log units) below the measured number; measured number outside the range, above it.
By their numbers in this assay, from the lowest: compounds 1 and 2 (each within the scatter of the next); then compound 3.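

In this assay the group on the amide-type nitrogen proves able to move the number: the fluoro change between compound 1 and compound 2 stayed within the scatter, but 2-methylphenyl in place of 3-fluorophenyl gives a 9.4-fold higher number from compound 2 to compound 3 (0.97 log units; beyond the scatter) and 2-methylphenyl in place of 3,4-difluorophenyl gives an 11-fold higher number from compound 1 to compound 3 (1.06 log units; beyond the scatter) as well. So this position is not indifferent to what the aromatic ring carries, and this change leads to weaker inhibition. Nothing available explains the shift.

Still open, going by these compounds, is whether the methyl group itself or its different place on the ring carries the step, as both differ at once in compound 3. Also open, on these data alone, is how a chloro or methoxy group on that ring would read.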